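The compounds below may be only part of what the source reports. "The series", "measured", "known", "first", "only" and "open" are said of these compounds alone.

Measured in an ADME assay on L6 cells (Rattus norvegicus) for cytotoxicity; on this read-out higher numbers stand for weaker inhibition and lower numbers for stronger inhibition:
Compound 1, `CC(C)NC(=N)c1ccc(-c2cc3cc(C(=N)NC(C)C)ccc3o2)cc1`, gives > 198000 nM, a limit of the assay rather than a number.
Compound 2, `N=C(N)c1ccc(-c2cc3ccc(C(=N)N)cc3o2)cc1`, gives 800 nM.
Compound 3, `COc1cc(C(=N)NC(C)C)cc2cc(-c3ccc(C(=N)NC(C)C)cc3)oc12`, gives > 190000 nM, again a limit rather than a number.

The step that the two limits leave unreadable from compound 1 to compound 3 cannot be read because the limit of > 198000 nM in this assay, at which 1 of the 3 values shown sits, and the limit of > 190000 nM in this assay, at which 1 of the 3 values shown sits, are the limits at which both values sit. The difference between the cores of compound 1 and compound 2 is not broken down here; compound 2 is the only one of the three with a number in this assay.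

Compound 4, `COc1cc(C(=N)N)ccc1-c1cc2ccc(C(=N)N)cc2o1`, is not yet measured. It differs from compound 2 by methoxy in place of hydrogen on an aromatic carbon, the same kind of change as methoxy in place of hydrogen on an aromatic carbon from compound 1 to compound 3, though not at the same place: in compound 4 the methoxy sits on a six-membered aromatic ring of carbon only, ortho to a large group and meta to a group of 3 heavy atoms, whereas in compound 3 it sits on a ring that is part of a fused system of two rings, ortho and meta to a fused ring and meta to a group of 6 heavy atoms. Since the measured step of the same kind is unreadable, the expected step of a 1.9-fold higher number from compound 2 to compound 4 (0.27 log units; within the scatter) rests on compound 2 alone, whose value is 800 nM, and on the change adding only 2 heavy atoms. Compound 4 is therefore estimated at 1500 nM, expected between 300 nM and 8000 nM.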

Compound 4, half-maximal inhibitory concentration: 108000 nM
Compound 4: the middle estimate sits 72-fold (1.86 log units) below what was measured; measured number above the stated range.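

In this assay, methoxy in place of hydrogen on an aromatic carbon gives a 140-fold higher number from compound 2 to compound 4 (2.13 log units; beyond the scatter), so on the core of compound 2 this change is far from neutral. The same kind of change from compound 1 to compound 3 cannot be read, because both compounds sit at limits of the assay rather than at numbers: the limit of > 198000 nM in this assay, at which 1 of the 4 values shown sits, and (the limit of > 190000 nM in this assay, at which 1 of the 4 values shown sits). The large step therefore holds for the core of compound 2 and for this one place only, and nothing shows that it carries over to the core of compound 1.

On these data alone, it stays open whether the step follows methoxy itself or the place, ortho to a large group. An amine or a carboxylic acid at that place would test this, and methoxy at the same place on the core of compound 1 would test the carry-over.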